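This account rests on a few compounds, and the source may have more. Where it says the series, first, only, none or still open, it means among the compounds named here.

Among the measured compounds shown here, compound 1 `O=C(COc1ccc(C(=O)/C=C/c2ccccc2Cl)cc1)N[C@H]1CCOC1=O` is the only member of the set with a numerical result: in a functional assay on DU-145 cells (Homo sapiens) for antiproliferative activity, read by MTT assay, with a stated time of 72 h (on this read-out lower numbers stand for stronger inhibition and higher numbers for weaker inhibition), compound 1 gives 3240 nM. Compound 2 `CCCCCCCCCCSC(=S)N[C@H]1CCOC1=O` reaches only the limit of the assay, > 64000 nM, and not a number. Compound 3 `O=C(CNc1ccc(Cl)cc1Cl)N[C@H]1CCOC1=O` likewise sits at a limit, > 64000 nM, with no number behind it. For the measured compounds named here, the measured picture is therefore dominated by the limit of > 64000 nM in this assay, at which 2 of the 3 values shown sit, which leaves compound 1 as the single reference point on the scale, and no measured pair tells how a change at the varying position moves the read-out.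

Compound 4 `O=C(COc1ccc(C(=O)/C=C/c2cccc(Br)c2)cc1)N[C@H]1CCOC1=O` is not yet measured. It differs from compound 1 in one place: 3-bromophenyl in place of 2-chlorophenyl on a double-bonded chain carbon bound to a double-bonded chain carbon. Going by the values given here, no measured pair isolates a change of this kind, so the size of the step rests on the change itself: one halogenated phenyl exchanged for another with the same count of heavy atoms and the same absence of donors and acceptors. In this assay a shift beyond the usual scatter is not expected in either direction; the step from compound 1 to compound 4 is estimated at a 1.1-fold lower number from compound 1 to compound 4 (0.03 log units; within the scatter). Compound 4 is accordingly expected to give 3000 nM, with a likely range of 1200 nM to 8000 nM.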

Compound 4, half-maximal inhibitory concentration: 9800 nM
Compound 4: the middle estimate sits 3.3-fold (0.51 log units) below what was measured; the measured number lies above the stated range.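

Among the compounds shown here, this is the first measured pair, and it shows that the group on the double-bonded chain carbon bound to a double-bonded chain carbon is not a silent position in this assay: 3-bromophenyl in place of 2-chlorophenyl gives a 3.0-fold higher number from compound 1 to compound 4 (0.48 log units; beyond the scatter). The two groups match in heavy-atom count and both have no hydrogen-bond donors or acceptors, so a change that leaves these counts untouched can still move the read-out beyond the scatter. The step is toward weaker inhibition, yet compound 4 still gives a number on the scale and does not reach the assay limit.

On these data alone, the pair changes the halogen and its numbered place on the phenyl ring together, so which of the two carries the step stays open; 3-chlorophenyl and 2-bromophenyl would separate them, and an aminophenyl or carboxyphenyl group would test the same place with a different kind of substituent. The series also remains thinly anchored, with few numbers for comparison: the limit of > 64000 nM in this assay, at which 2 of the 4 values shown sit.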